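Removing a Methoxy Group from Compound 3

This account rests on a few compounds, and the source may have more. Where it says the series, first, only, none or still open, it means among the compounds named here.

Compound 3 `COc1cc(/C=N/NC(=O)c2ccncc2)cc(O)c1O` stands second highest of three numbers in a functional assay on cells (Mus musculus) for cytotoxicity, read by MTT assay, with a stated time of 24 h, tested at 10 uM (on this read-out lower numbers stand for a weaker effect and higher numbers for a stronger effect at the one concentration tested), where compound 3 gives 80%. Its nearest neighbour is compound 1 `COc1cc(/C=N/NC(=O)c2ccncc2)cc(OC)c1O`, which in this assay gives 65%, and the furthest is compound 2 `COc1cc(/C=N/N(C)c2nc3ccccc3s2)cc(OC)c1O`, which in this assay gives 110%. Compound 4 `O=C(N/N=C/c1ccc(O)c(O)c1)c1ccncc1` differs from compound 3 by hydrogen in place of methoxy on an aromatic carbon. Among the compounds with values here, the one measured step that bears on this is a number 15 percentage points higher from compound 1 to compound 3 (beyond the scatter), a change on the same part of the shared core. That step was modest, and taking away a whole methoxy group is a different kind of change, so compound 4 is expected to shift by a number 5 percentage points higher from compound 3 to compound 4 (within the scatter), a step that may well stay within the scatter. The estimate for compound 4 in this assay is 85%, between 65% and 105%.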

Compound 4, a percentage reported as activity, at one concentration (the size of the read-out at that concentration, not a potency) in the Mus musculus assay: 101%
Estimate against measurement, compound 4: 16 percentage points below; the range from low to high includes it.
By their numbers in the Mus musculus assay, from the lowest: compound 1; then compound 3; then compounds 4 and 2 (each within the scatter of the next).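

In the Mus musculus assay the methoxy group proves dispensable on this aromatic carbon, as its removal gives a number 21 percentage points higher from compound 3 to compound 4 (beyond the scatter) and so a stronger effect, with compound 3 at 80% and compound 4 at 101%. That gain does not carry over to a physicochemical assay on cells (Homo sapiens), with a stated time of 18 h, tested at 10 uM (a lower number here means a stronger effect, a higher number a weaker effect of the compound at the concentration tested), where compound 3 gives 8% and compound 4 gives 4% and the same change gives a number 4 percentage points lower from compound 3 to compound 4 (within the scatter) so the two compounds cannot be told apart. Nothing shown gives a reason for this difference between the two read-outs.

Still open, going by these compounds, is how an amine or a longer chain on this aromatic carbon would read in the Mus musculus assay once hydrogen has replaced the methoxy group.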